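The source may report more compounds than this note shows. Statements on the series, on what has been measured and on what is new or still open speak of the compounds shown alone.

Three compounds sharing one core were measured in an assay on HEK293 cells for displacement of a labelled ligand from Neuronal acetylcholine receptor; alpha4/beta2 (Homo sapiens), read by scintillation counting, with a stated time of 120 min; a higher number here means a weaker inhibitor, a lower number a stronger inhibitor. Compound 1 `FCCOc1cccc(-c2cn([C@H]3CN4CCC3CC4)nn2)c1` gives 7050 nM, compound 2 `FCCCOc1cccc(-c2cn([C@H]3CN4CCC3CC4)nn2)c1` gives 9010 nM, and compound 3 `c1ccc(COc2cccc(-c3cn([C@H]4CN5CCC4CC5)nn3)c2)cc1` gives 5060 nM. Compound 3 has the lowest of the three numbers, yet a 1.4-fold lower number from compound 1 to compound 3 (0.14 log units; within the scatter) and a 1.8-fold lower number from compound 2 to compound 3 (0.25 log units; within the scatter) both lie within the scatter, as does a 1.3-fold higher number from compound 1 to compound 2 (0.11 log units; within the scatter), so the three stand together. Compound 4 `Fc1cccc(-c2cn([C@H]3CN4CCC3CC4)nn2)c1` differs from compound 3 by fluoro in place of benzyloxy on an aromatic carbon. Among the measured compounds shown here, no measured step removes the oxygen-bearing group itself; the known steps only exchange what hangs on that oxygen. The change to compound 4 is therefore weakly anchored, and no step beyond the scatter is expected in this assay, a 1.2-fold higher number from compound 3 to compound 4 (0.07 log units; within the scatter). Compound 4 is accordingly estimated at 6000 nM, with a range from 1500 nM to 25000 nM.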

Compound 4, inhibition constant: 5200 nM
Estimate against measurement, compound 4: 1.2-fold (0.06 log units) above; the measured number falls inside the stated range.
By their numbers in this assay, from the lowest: compounds 3, 4, 1 and 2 (each within the scatter of the next).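

In (this assay), the whole oxygen-bearing group on this aromatic carbon can give way to fluoro with no step beyond the scatter, whichever chain it carried (a 1.0-fold higher number from compound 3 to compound 4 (0.01 log units; within the scatter); a 1.7-fold lower number from compound 2 to compound 4 (0.24 log units; within the scatter); a 1.4-fold lower number from compound 1 to compound 4 (0.13 log units; within the scatter)). Fluoro, a single atom, thus stands level with benzyloxy, with its eight heavy atoms and aromatic ring, as well as with 3-fluoropropoxy and 2-fluoroethoxy. Nothing available explains this flat result. Going by these compounds, whether an amine or a carboxylic acid on this aromatic carbon would give a step beyond the scatter remains open.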